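Replacing Pyrazin-2-yl with 1,3-Thiazol-5-yl on Compound 3

The source may hold more compounds than are shown below. What is called first, only, known or untested is meant among the compounds shown, and "the series" means these compounds.

Of the compounds shown here, three have been measured in an in vitro ADME assay on microsomes from liver (Homo sapiens) for metabolic stability; on this read-out higher numbers stand for fast clearance and lower numbers for slow clearance. Compound 1 (`O=C(COCc1ccncc1)N1CCN(c2ccc(Cl)cc2F)CC1`) gives 38 mL.min-1.g-1, compound 2 (`O=C(COCc1ccccn1)N1CCN(c2ccc(Cl)cc2Cl)CC1`) gives 94 mL.min-1.g-1, and compound 3 (`O=C(COCc1cnccn1)N1CCN(c2ccc(Cl)cc2Cl)CC1`) gives 4 mL.min-1.g-1, the lowest number of the three. Compound 4 (`O=C(COCc1cncs1)N1CCN(c2ccc(Cl)cc2Cl)CC1`) carries 1,3-thiazol-5-yl in place of pyrazin-2-yl on a saturated chain carbon bound to an oxygen on a saturated carbon. Among the compounds with values here, one measured step bears on this place: a 24-fold lower number from compound 2 to compound 3 (1.37 log units; beyond the scatter), a large move, made with pyrazin-2-yl in place of pyridin-2-yl. Compound 1 differs from compound 3 in more than one place, so its value offers only a loose comparison. Within the data shown here, no measured compound carries a five-membered ring at this place. The low number of compound 3, 4 mL.min-1.g-1, has been seen with pyrazin-2-yl alone, while compound 2 reaches 94 mL.min-1.g-1 with pyridin-2-yl. A clear move to a higher number, a 5.0-fold higher number from compound 3 to compound 4 (0.70 log units; beyond the scatter), is therefore expected, though smaller than the measured step. For compound 4 the estimate is 20 mL.min-1.g-1, with an expected range from 7 mL.min-1.g-1 to 70 mL.min-1.g-1.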

Compound 4, intrinsic clearance in microsomes: 73 mL.min-1.g-1
Beside the measured number, compound 4's estimate is 3.7-fold (0.56 log units) below it; the whole stated range lies below it.
By their numbers in this assay, from the lowest: compound 3; then compounds 1, 4 and 2 (each within the scatter of the next, the first and the last beyond it).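

At this place, on a saturated chain carbon bound to an oxygen on a saturated carbon, this assay gives an 18-fold higher number from compound 3 to compound 4 (1.26 log units; beyond the scatter), a large step that takes the low number away once pyrazin-2-yl leaves. The five-membered ring and pyridin-2-yl cannot be told apart, with a 1.3-fold lower number from compound 2 to compound 4 (0.11 log units; within the scatter), so among compounds 2, 3 and 4, which differ only at this place, pyrazin-2-yl alone stands apart from the other two rings. Nothing at hand explains why these rings differ in this way.

Going by these compounds, it remains open whether a pyrimidin-5-yl or a 1,3-oxazol-5-yl group at this place would match compound 3 or instead match compound 2 and compound 4. On these data alone, it is also open whether the step holds when the rest of the molecule differs from that of compound 3.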